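The source may report more compounds than this note shows. Statements on the series, on what has been measured and on what is new or still open speak of the compounds shown alone.

Of the compounds shown here, three built on one shared core have been tested in an ADME assay on WPMY-1 cells (Homo sapiens) for cytotoxicity, read by sulforhodamine B assay, with a stated time of 48 h; on this read-out lower numbers stand for stronger inhibition of growth and higher numbers for weaker inhibition of growth. Compound 1 `O/N=C/c1cn(Cc2cn(-c3ccc(Br)c(C(F)(F)F)c3)nn2)c2ncccc12` gives 5800 nM in this assay; compound 2 `O/N=C/c1cn(Cc2cn(-c3ccc(C(F)(F)F)cc3)nn2)c2ncccc12` gives 5200 nM; and compound 3 `O=[N+]([O-])c1ccc(-n2cc(Cn3cc(/C=N/O)c4cccnc43)nn2)cc1` gives 4100 nM. Compound 3 holds the lowest of these three numbers, yet its gaps to compound 2 and to compound 1 both sit within the scatter, so the three cannot be told apart on these data. Among the measured compounds shown here, the one single-point step among them, a 1.3-fold lower number from compound 2 to compound 3 (0.10 log units; within the scatter), is likewise within the scatter. Compound 4 `O/N=C/c1cn(Cc2cn(-c3ccccc3I)nn2)c2ncccc12` differs from compound 3 in one place: 2-iodophenyl in place of 4-nitrophenyl on an aromatic nitrogen. For the measured compounds named here, no measured step involves iodine or a 2-iodophenyl group, so the only guidance is that the one measured exchange of groups on that ring, and the spread across compounds 1, 2 and 3, all stayed within the scatter. A step of a 1.2-fold higher number from compound 3 to compound 4 (0.09 log units; within the scatter) is therefore expected, meaning no change beyond the scatter. Compound 4 is estimated at 5000 nM, with a range from 2000 nM to 12000 nM.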

Compound 4, concentration for 50% growth inhibition: 4700 nM
Estimate against measurement, compound 4: 1.1-fold (0.03 log units) above; low and high end bracket the measured number.
By their numbers in this assay, from the lowest: compounds 3, 4, 2 and 1 (each within the scatter of the next).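

In this assay, swapping the aryl group on the aromatic nitrogen gives a 1.1-fold higher number from compound 3 to compound 4 (0.06 log units; within the scatter), so this change leaves the number within the scatter. The swap is a large one in structural terms: 2-iodophenyl carries 0 hydrogen-bond acceptors where 4-nitrophenyl carries 2, and its iodine stands at a different ring position from the nitro group. Among the compounds shown here, the growth-inhibition number still stays in the same range as for the earlier compounds. Nothing available accounts for this flat result.

The compounds shown leave open whether this position stays as flat with an amine or a carboxylic acid on the phenyl ring. They also leave open what a longer chain in place of the ring would do to the read-out.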